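The source may report more compounds than this note shows. Statements on the series, on what has been measured and on what is new or still open speak of the compounds shown alone.

Working notes on the series. Among the measured compounds shown here, compound 2 `O=C(Cn1cc(-c2ccncc2)nn1)Nc1nccs1` gives the lowest number of the three measured so far in a functional assay on BMDM cells (Mus musculus, strain C57BL/6) for inhibition, with a stated time of 2 days (a higher number here means a weaker inhibitor, a lower number a stronger inhibitor), namely 2 nM. The nearest is compound 3 `Cc1csc(NC(=O)Cn2cc(-c3ccncc3)nn2)n1`, which gives 100 nM in this assay; the step of a 50-fold higher number from compound 2 to compound 3 (1.70 log units; beyond the scatter) is large and corresponds to a methyl in place of hydrogen on an aromatic carbon. The furthest is compound 1 `Cc1csc(NC(=O)Cn2cc(-c3cccc(N)c3)nn2)n1`, with 250 nM in this assay. Compound 4 `O=C(Cn1cc(-c2cccc(Cl)c2)nn1)Nc1nccs1` is next to be measured; it differs from compound 2 as follows: 3-chlorophenyl in place of pyridin-4-yl on an aromatic carbon. The measured step that bears on this is a 2.5-fold lower number from compound 1 to compound 3 (0.40 log units; beyond the scatter), where pyridin-4-yl replaced 3-aminophenyl, a modest change; read in reverse, moving off pyridin-4-yl to a substituted phenyl is expected to raise the number. For the measured compounds named here, no measured step covers 3-chlorophenyl itself, so the expectation is loose. Compound 4 is therefore expected to give a higher number than compound 2 in this assay, a modest step of a 5.0-fold higher number from compound 2 to compound 4 (0.70 log units; beyond the scatter) beyond the scatter. The estimate for compound 4 in this assay is 10 nM, with a range from 2 nM to 60 nM.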

Compound 4, half-maximal inhibitory concentration: > 30000 nM
Compound 4 gave a limit, no number; the forecaster's own chance of this, stated with the estimate: 2%; middle value at least 3000-fold (3.47 log units) away from the limit.
By their numbers in this assay, from the lowest: compound 2; then compound 3; then compound 1. At a limit, above all of these: compound 4.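

The change to 3-chlorophenyl gives an at least 15000-fold higher number from compound 2 to compound 4 (4.17 log units; beyond the scatter) in this assay, so the group on this aromatic carbon of the five-membered ring can decide nearly all of the inhibition on the unmethylated core. Among the compounds shown here, the only earlier step at this position, a 2.5-fold lower number from compound 1 to compound 3 (0.40 log units; beyond the scatter), was modest and was measured on the methyl-bearing core, and it gave no sign of a change this large. The figure for compound 4 is a limit and not a number, so the true size of the step stays unknown: the limit of > 30000 nM in this assay, at which 1 of the 4 values shown sits.

The change removes the ring nitrogen, the one hydrogen-bond acceptor counted in the leaving group, and adds a chlorine, and the compounds shown cannot separate these two changes. Unsubstituted phenyl and pyridin-3-yl at this position, which would help to separate them, are not among the compounds shown.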